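The source may report more compounds than this note shows. Statements on the series, on what has been measured and on what is new or still open speak of the compounds shown alone.

Measured in a functional assay on A549 cells (Homo sapiens) for cytotoxicity, read by sulforhodamine B assay, with a stated time of 72 h; on this read-out lower numbers stand for stronger inhibition of growth and higher numbers for weaker inhibition of growth:
- compound 1 `C=C1CC[C@@H]2[C@](C)(CCC[C@]2(C)C(=O)O)[C@H]1CCc1ccc2c(c1)C(=O)C=CC2=O`: > 7400 nM (a limit of the assay, not a number)
- compound 2 `C=C1CC[C@@H]2[C@](C)(CCC[C@]2(C)C(=O)OC)[C@H]1CCc1ccc2c(c1)C(=O)C=CC2=O`: 200 nM
- compound 3 `C=C1CC[C@@H]2[C@](C)(CCC[C@]2(C)C(=O)O)[C@H]1CCc1ccc2c(OC(C)=O)ccc(OC(C)=O)c2c1`: 240 nM

Compound 3 at 240 nM and compound 2 at 200 nM lie within the usual scatter of each other, so they count as level. The next compound, compound 4 `C=C1CC[C@@H]2[C@](C)(CCC[C@]2(C)C(=O)OC)[C@H]1CCc1ccc2c(OC(C)=O)ccc(OC(C)=O)c2c1`, differs from compound 3 in one place: methyl in place of hydrogen on an oxygen next to a carbonyl group. Its carboxy thus becomes methoxycarbonyl.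

Going by the values given here, only one measured step bears on this, the same change made on a different partner: an at least 37-fold lower number from compound 1 to compound 2 (1.56 log units; beyond the scatter). That is a large step, but it is a single pair. It also starts from compound 1, which sits at the limit of > 7400 nM in this assay, at which 1 of the 3 values shown sits, so its true size is not known. Compound 3 still carries the free acid and already gives 240 nM, unlike compound 1. A lower number is therefore expected again in this assay, but a clearly smaller step than the one seen before. For compound 4 the expected value is 80 nM, with an estimated range of 15 nM to 350 nM. This estimate amounts to a 3.0-fold lower number from compound 3 to compound 4 (0.48 log units; beyond the scatter), an expected step that has not been measured.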

Compound 4, concentration for 50% growth inhibition: 120 nM
Estimate against measurement, compound 4: 1.5-fold (0.18 log units) below, within the range that was stated.
By their numbers in this assay, from the lowest: compounds 4, 2 and 3 (each within the scatter of the next). At a limit, above all of these: compound 1.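

In this assay, placing methyl on an oxygen next to a carbonyl group, which turns carboxy into methoxycarbonyl, gives a 2.0-fold lower number from compound 3 to compound 4 (0.30 log units; within the scatter), so on this core the change makes no difference that can be told from the usual scatter of repeated measurements. The large effect seen earlier therefore does not carry over from one core to the other, and the size of this change depends on the core that carries it: the same change on two cores in this assay, an at least 37-fold lower number (1.56 log units; beyond the scatter) from compound 1 to compound 2 and a 2.0-fold lower number (0.30 log units; within the scatter) from compound 3 to compound 4, at least 18-fold (1.26 log units) apart, beyond the scatter of two such steps Compound 1 stands at > 7400 nM, which is a limit of the assay and not a number.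

On these data alone, it remains open whether an ethyl group or a longer chain on the same oxygen, or an amide in place of the methoxycarbonyl group, would give numbers level with those of compound 3 and compound 4 in this assay. The compounds shown also cannot tell why the free carboxy group goes with such different results on the two cores, and a second pair on each core would be needed to test how firm this contrast is.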